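Swapping One Amide Substituent: A Solubility Expectation

The compounds below may be only part of what the source reports. "The series", "measured", "known", "first", "only" and "open" are said of these compounds alone.

Compound 1 `Cn1ccc2ccc(-c3cc(Nc4ccccc4S(=O)(=O)N4CCOCC4)cc4nccnc34)cc21` gives 5 ug/mL in solution
Compound 2 `Cn1cc(NC(=O)c2ccncc2Nc2cc(-c3ccc4ccn(C)c4c3)c3nccnc3c2)cn1` gives 2 ug/mL in solution

Both numbers come from a physicochemical assay for solubility, read by spectrophotometry, measured as kinetic solubility, at pH 8, tested at 500 uM (on this read-out higher numbers stand for higher solubility and lower numbers for lower solubility), and both compounds share the same core. Compound 2 stands lower of the two, and its gap to compound 1 lies beyond the scatter. These two compounds differ in more than one place, so their gap says nothing about any single structural change.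

The next compound is compound 3 `Cn1ccc2ccc(-c3cc(Nc4cnccc4C(=O)NCC4COCCN4)cc4nccnc34)cc21` and it differs from compound 2 at the amide alone. The change is (morpholin-3-yl)methyl in place of 1-methyl-1H-pyrazol-4-yl on an amide-type nitrogen and it puts (morpholin-3-yl)methyl in place of 1-methyl-1H-pyrazol-4-yl on an amide-type nitrogen. Among the measured compounds shown here, no measured pair shows this change, so what follows is a judgement from the structures alone, and an uncertain one.

An upward move is expected in this assay and it is estimated as a 20-fold higher number from compound 2 to compound 3 (1.30 log units; beyond the scatter) and thus beyond the scatter. For compound 3 the estimate is 40 ug/mL with 8 ug/mL to 150 ug/mL as the expected range.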

Compound 3, solubility: 239 ug/mL
For compound 3 the middle estimate is 6.0-fold (0.78 log units) below the measured one, and the stated range ends below it.
By their numbers in this assay, from the lowest: compound 2; then compound 1; then compound 3.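

This pair gives the only single-place step among the compounds shown, so the amide-type nitrogen is the one position where a substituent can be read on its own. In this assay, (morpholin-3-yl)methyl in place of 1-methyl-1H-pyrazol-4-yl on that nitrogen goes with a 120-fold higher number from compound 2 to compound 3 (2.08 log units; beyond the scatter), a large step, which shows that this one substituent can shift the read-out well beyond the usual scatter while the rest of the molecule stays fixed. Nothing measured here explains why the step is so large.

The swap alters several features at once: a five-membered aromatic ring gives way to a six-membered non-aromatic ring, and the entering group carries a hydrogen-bond donor that the leaving group lacks, so a single step cannot show which of these features counts. Also open, as far as these compounds go, is whether a similar step would appear at this nitrogen with a piperidine ring, a simple amine on a longer chain or a carboxylic acid, or whether it belongs to the morpholine ring alone.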